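The compounds below may be only part of what the source reports. "The series", "measured", "known", "first", "only" and "open" are said of these compounds alone.

Measured so far in a functional assay on Ehrlich cells (Mus musculus) for cytotoxicity, tested at 25 ug/mL; a lower number here means a weaker effect, a higher number a stronger effect of the compound at the concentration tested:
compound 1 `COc1cc(N2C(N)=C(C#N)C(c3c(O)ccc4ccccc34)C3=C2CC(C)(C)CC3=O)cc(OC)c1OC` gives 10%
compound 2 `COc1cc(N2C(N)=C(C#N)C(/C=C/c3ccccc3)C3=C2CC(C)(C)CC3=O)cc(OC)c1OC` gives 30%

Among the measured compounds shown here, of these two numbers compound 2 stands highest, with compound 1 the only neighbour and the step of a number 20 percentage points higher from compound 1 to compound 2 (beyond the scatter) separating them. The unmeasured compound 3 `COc1cc(N2C(N)=C(C#N)C(c3ccc(Cl)cc3Cl)C3=C2CC(C)(C)CC3=O)cc(OC)c1OC` follows from compound 2 by one change, (2,4-dichlorophenyl in place of 2-phenylethenyl on a saturated ring carbon). For the measured compounds named here, the only measured step that touches the same saturated ring carbon is a number 20 percentage points higher from compound 1 to compound 2 (beyond the scatter), where one aromatic group gave way to 2-phenylethenyl and the read-out rose modestly. The change to compound 3 puts an aromatic group, 2,4-dichlorophenyl, back onto that carbon; the two compounds that carry aromatic groups there, compound 1 and compound 3, are not otherwise comparable, so the guidance is thin. A small downward step, close to the scatter, is expected, a number 10 percentage points lower from compound 2 to compound 3 (within the scatter). Compound 3 is therefore estimated at 20%, within 5% to 40%.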

Compound 3, a percentage reported as activity, at one concentration (the size of the read-out at that concentration, not a potency): 55%
Estimate against measurement, compound 3: 35 percentage points below; measured number above the stated range.
By their numbers in this assay, from the lowest: compound 1; then compound 2; then compound 3.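

In this assay, placing 2,4-dichlorophenyl on the saturated ring carbon in place of 2-phenylethenyl gave a number 25 percentage points higher from compound 2 to compound 3 (beyond the scatter) and so showed that the earlier rise had not reached the top of what this position allows. Replacing 2-hydroxynaphthalen-1-yl with 2,4-dichlorophenyl gave a number 45 percentage points higher from compound 1 to compound 3 (beyond the scatter) on an otherwise shared core, so the identity of the aromatic group on this carbon can matter greatly, and an aromatic group there does not in itself keep the read-out low. Nothing available explains why these groups differ in this way.

Whether the two chlorines are needed remains open, as the compounds shown do not include an unsubstituted phenyl or a 4-chlorophenyl group on this carbon. How a 4-methoxyphenyl group or an amine-bearing phenyl group would read there is also unknown.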